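The source may hold more compounds than are shown below. What is called first, only, known or untested is meant among the compounds shown, and "the series" means these compounds.

Measured so far:
compound 1, `Cc1cc(C)n(-c2cc(-c3ccccc3)nc(=O)[nH]2)n1` — 10000 nM
compound 2, `Cc1cc(C2CC2)n(-c2nc(C(F)(F)F)cc(=O)[nH]2)n1` — 78000 nM

In an ADME assay on CHO cells (Cricetulus griseus) for cytotoxicity, read by MTT assay (a higher number here means a weaker inhibitor, a lower number a stronger inhibitor), compound 1 gives 10000 nM. Going by the values given here, compound 2 stands at the highest number of the two, with compound 1 as its only neighbour at a lower number, a gap that lies beyond the scatter. Among the compounds with values here, no pair measured so far differs in one place only, so no single step is known on this series.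

Compound 3, `Cc1cc(Nc2ccc(F)cc2)n(-c2nc(C(F)(F)F)cc(=O)[nH]2)n1`, has not yet been measured in this assay. It differs from compound 2 in one place:
(4-fluorophenyl)amino in place of cyclopropyl on an aromatic carbon

With no measured step of this kind at hand, the expectation rests only on the two numbers shown. Compound 1 shows that a lower number than that of compound 2 is reachable in this set, and the change adds a larger group in place of a small one. For compound 3 a step of a 2.6-fold lower number from compound 2 to compound 3 (0.41 log units; beyond the scatter) is expected, toward a lower number, of a size that should lie beyond the scatter but short of the gap between compound 2 and compound 1. Compound 3 is therefore estimated at 30000 nM, with a range from 8000 nM to 100000 nM.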

Compound 3, half-maximal inhibitory concentration in the CHO assay: 20000 nM
Compound 3: middle estimate off by 1.5-fold (0.18 log units), on the high side; low and high end bracket the measured number.
By their numbers in the CHO assay, from the lowest: compounds 1 and 3 (each within the scatter of the next); then compound 2.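

Going by these compounds alone, at the aromatic carbon next to the ring nitrogen, this pair gives the first single-change reading on the series: in the CHO assay, (4-fluorophenyl)amino in place of cyclopropyl gives a 3.9-fold lower number from compound 2 to compound 3 (0.59 log units; beyond the scatter). The number at this position therefore responds to the group it carries, and here the larger group, with its aromatic ring and its hydrogen-bond donor, goes with the lower number, on this one pair only. The same change also lowers the number in a physicochemical assay for solubility, at pH 7.4 (on this read-out higher numbers stand for higher solubility and lower numbers for lower solubility), where compound 2 gives 160000 nM and compound 3 gives 15000 nM. So the lower number in the CHO assay comes with lower solubility in the physicochemical assay: the measured solubility of compound 2, 160000 nM, and of compound 3, 15000 nM, an 11-fold lower number (1.03 log units; beyond the scatter)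

A single pair leaves the parts of the entering group unseparated, so the step cannot be assigned to the aromatic ring, the amino link or the fluorine. A plain phenylamino without the fluorine, or a morpholine at the same carbon, would show whether the lower number in the CHO assay and the loss of solubility in the physicochemical assay must travel together or can be pulled apart.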